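This account rests on a few compounds, and the source may have more. Where it says the series, first, only, none or still open, it means among the compounds named here.

Measured so far in a functional assay on A549 cells (Homo sapiens) for inhibition, read by ELISA, with a stated time of 24 h; a higher number here means a weaker inhibitor of growth, a lower number a stronger inhibitor of growth:
- Compound 1 `O=C(Cl)/C=C/c1ccccc1OC(=O)c1ccccc1`: > 100000 nM, a limit
- Compound 2 `CO/N=C/C=C/c1ccccc1OC(=O)c1ccccc1`: > 100000 nM, a limit
- Compound 3 `O=C(/C=C/c1ccccc1O)NO`: 55200 nM

Compound 1 gives no number, only the limit > 100000 nM. This is the limit of > 100000 nM in this assay, at which 2 of the 3 values shown sit. Compound 4 `CN1CCN(C(=O)/C=C/c2ccccc2OC(=O)c2ccccc2)CC1` differs from it by 4-methylpiperazin-1-yl in place of chloro on a carbonyl carbon, with 4-methylpiperazin-1-yl in place of chloro on a carbonyl carbon. Among the measured compounds shown here, the one measured step that touches this group, a step that the two limits leave unreadable from compound 1 to compound 2, has no readable size. Only compound 3 gives a number, 55200 nM, so no measured size carries over to this change. Only a small gain in growth inhibition is expected, an estimated at least 1.4-fold lower number from compound 1 to compound 4 (0.15 log units; that floor lies within the scatter). Compound 4 is expected near 70000 nM, with an estimated range of 15000 nM to 200000 nM.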

Compound 4, concentration for 50% growth inhibition: > 100000 nM
Compound 4: no number, only a limit; the forecaster's own chance of this, stated with the estimate: 55%; at least 1.4-fold (0.15 log units) between middle value and limit.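

Among the compounds shown here, compound 1 and compound 4 each give only a limit, not a number, so no step between them can be read: the limit of > 100000 nM in this assay, at which 3 of the 4 values shown sit. The compounds shown leave open whether 4-methylpiperazin-1-yl in place of chloro on a carbonyl carbon changes growth inhibition at all.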